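The source may hold more compounds than are shown below. What is called first, only, known or untested is meant among the compounds shown, and "the series" means these compounds.

Measured compounds:
- Compound 1 `O=C(O)COc1ccc([C@H]2CC[C@]3(CC2)OOC2(O3)C3CC4CC(C3)CC2C4)cc1Cl`: < 7 mL.min-1.g-1
- Compound 2 `O=C(O)CNC(=O)COc1ccc([C@H]2CC[C@]3(CC2)OOC2(O3)C3CC4CC(C3)CC2C4)cc1`: < 7 mL.min-1.g-1

In an ADME assay on microsomes from liver (Homo sapiens) for metabolic stability, using NADPH, with a stated time of 60 min, in the presence of a further agent that is not named here (a lower number here means slower removal, a higher number faster removal of the compound), compound 1 gives < 7 mL.min-1.g-1, which is a limit of the assay and not a number. Compound 2 gives < 7 mL.min-1.g-1, also a limit. Both compounds therefore sit at the same point: the limit of < 7 mL.min-1.g-1 in this assay, at which 2 of the 2 values shown sit.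

Compound 3 `O=C(O)COc1ccc([C@H]2CC[C@]3(CC2)OOC2(O3)C3CC4CC(C3)CC2C4)cc1C(=O)O` has carboxy in place of chloro on an aromatic carbon, ortho to a carboxymethoxy group: carboxy in place of chloro on an aromatic carbon. Within the data shown here, no measured step shows what this swap does, so no change beyond the scatter is expected. The expected step is a step that the limit leaves unreadable from compound 1 to compound 3. For compound 3, the estimate is 5 mL.min-1.g-1, with an expected range of 3 mL.min-1.g-1 to 8 mL.min-1.g-1.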

Compound 3, intrinsic clearance in microsomes: < 7 mL.min-1.g-1
Compound 3: only a limit was reported (the forecaster's own chance of this, stated with the estimate: 85%); the middle value does not contradict the limit.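

No step can be read from compound 1 to compound 3, since both results are limits and not numbers: the limit of < 7 mL.min-1.g-1 in this assay, at which 3 of the 3 values shown sit. The compounds shown leave open what carboxy in place of chloro does to the rate of removal, and how they rank against each other.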